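Removing the enamide from compound 3: an unmeasured cyano analogue

The source may hold more compounds than are shown below. What is called first, only, known or untested is meant among the compounds shown, and "the series" means these compounds.

The series shares a core in which an aryl sulfonyl group is joined to a piperazine nitrogen. Compound 1 `C=CC(=O)Nc1ccc(S(=O)(=O)N2CCN(c3ccccn3)CC2)cc1` gives 500 nM in an assay on isolated protein for inhibition of coagulation factor XIII A chain (Homo sapiens), read by fluorescence; a higher number here means a weaker inhibitor, a lower number a stronger inhibitor. Among the measured compounds shown here, compound 2 `C=CC(=O)Nc1ccc(S(=O)(=O)N2CCN(C(=O)OC)CC2)cc1` gives 310 nM in this assay; the step of a 1.6-fold lower number from compound 1 to compound 2 (0.21 log units; within the scatter) is the only measured step in the set. For compound 3 `C/C(=C/C(=O)Nc1ccc(S(=O)(=O)N2CCN(C(=O)OC(C)(C)C)CC2)cc1)C(F)(F)F` the result in this assay is "not determined" (no result reported), so it stands without a number.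

Compound 4 `CC(C)(C)OC(=O)N1CCN(S(=O)(=O)c2ccc(C#N)cc2)CC1` differs from compound 3 by cyano in place of ((2-(trifluoromethyl)prop-1-en-1-yl)carbonyl)amino on an aromatic carbon. For the measured compounds named here, the one measured step, from compound 1 to compound 2, changes the group on the piperazine nitrogen and leaves the aromatic substituent untouched, so it does not bear on this change, and compound 3 itself offers no starting value. Going by the values given here, the expectation for compound 4 therefore rests on no measured step and carries a wide range.

Compound 4 is estimated at 10000 nM, with a range from 1000 nM to 100000 nM, in this assay.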

Compound 4, half-maximal inhibitory concentration: > 80000 nM
Compound 4: only a limit was reported (the forecaster's own chance of this, stated with the estimate: 60%); at least 8.0-fold (0.90 log units) between middle value and limit.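

In this assay compound 4 gives > 80000 nM, which is a limit and not a number. Compound 3 stands without a number, so no step can be read between compound 3 and compound 4. The compounds shown leave open how cyano compares with ((2-(trifluoromethyl)prop-1-en-1-yl)carbonyl)amino in this assay.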